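Replacing the imidazole on the amide nitrogen with an isoxazole

The compounds below may be only part of what the source reports. "The series", "measured", "known", "first", "only" and "open" are said of these compounds alone.

Measured compounds in a functional assay on CHO cells for agonist activity at Free fatty acid receptor 2 (Homo sapiens), read by cAMP accumulation; a higher number here means a weaker inhibitor, a lower number a stronger inhibitor:
- compound 1, `CC(C)[C@H](C(=O)Nc1ccc(F)cn1)c1ccc(Cl)cc1`, 1300 nM
- compound 2, `CC(C)[C@H](C(=O)Nc1cccnn1)c1ccc(Cl)cc1`, 2300 nM
- compound 3, `CC(C)[C@H](C(=O)Nc1ncc[nH]1)c1ccc(Cl)cc1`, 20000 nM

Compound 3 gives the highest number of the three, so it is the weakest of them in this assay. Its two steps from the other compounds both lie beyond the scatter: a 15-fold higher number from compound 1 to compound 3 (1.19 log units; beyond the scatter) and an 8.7-fold higher number from compound 2 to compound 3 (0.94 log units; beyond the scatter). Compound 4, `CC(C)[C@H](C(=O)Nc1ccon1)c1ccc(Cl)cc1`, is not yet measured. It differs from compound 3 in one place: 1,2-oxazol-3-yl in place of 1H-imidazol-2-yl on an amide-type nitrogen.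

Within the data shown here, the steps that bear on this change are those into compound 3, since compound 4 keeps a five-membered aromatic ring with two hetero atoms, like compound 3, but, like compounds 1 and 2, carries no hydrogen-bond donor on that ring. Both of those steps were large, so a move back toward the numbers of compounds 1 and 2 is expected, though not necessarily all the way. Compound 4 is therefore estimated at 5000 nM, between 1500 nM and 20000 nM, which is expected to mean a 4.0-fold lower number from compound 3 to compound 4 (0.60 log units; beyond the scatter).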

Compound 4, half-maximal inhibitory concentration: 36000 nM
The estimate for compound 4 lay 7.2-fold (0.86 log units) below the measured number; measured number above the stated range.
By their numbers in this assay, from the lowest: compounds 1 and 2 (each within the scatter of the next); then compounds 3 and 4 (each within the scatter of the next).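

In this assay, the 1,2-oxazol-3-yl group carries no hydrogen-bond donor, unlike the 1H-imidazol-2-yl group it replaces, yet the result is a 1.8-fold higher number from compound 3 to compound 4 (0.26 log units; within the scatter), so these two compounds cannot be told apart. The donor on the ring therefore does not account for the gap to the pyridazin-3-yl and 5-fluoropyridin-2-yl groups, as the new ring also stands well apart from them, with a 16-fold higher number from compound 2 to compound 4 (1.19 log units; beyond the scatter) and a 28-fold higher number from compound 1 to compound 4 (1.44 log units; beyond the scatter). No measurement shown explains that gap.

Going by these compounds, it remains open whether any five-membered aromatic ring on the amide-type nitrogen can reach the numbers of compound 1 and compound 2. A thiazole ring, or a methyl group or chlorine added to the 1,2-oxazol-3-yl ring, would help test this.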